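A Second Chloro Group on the Shared Core

The compounds below may be only part of what the source reports. "The series", "measured", "known", "first", "only" and "open" are said of these compounds alone.

Compound 2 `ClCc1ccccc1Cn1cnc2c(Cl)ncnc21` is the parent of one matched pair. In a functional assay on NCI-H460 cells (Homo sapiens) for cytotoxicity, read by sulforhodamine B assay, with a stated time of 48 h (a lower number here means a stronger inhibitor of growth, a higher number a weaker inhibitor of growth), compound 2 gives 15500 nM, while compound 1 `ClCc1ccccc1Cn1cnc2c(Cl)nc(Cl)nc21` gives 3310 nM in this assay. The change between them is chloro in place of hydrogen on an aromatic carbon, and it produced a 4.7-fold lower number from compound 2 to compound 1 (0.67 log units; beyond the scatter). Compound 3 `ClCc1cccc(Cn2cnc3ncnc(Cl)c32)c1` has the same atoms as compound 2 joined differently, but the difference between the two cores is not broken down here; in this assay compound 3 gives 2080 nM. Compound 4 `ClCc1cccc(Cn2cnc3nc(Cl)nc(Cl)c32)c1` has not yet been measured and differs from compound 3 by chloro in place of hydrogen on an aromatic carbon, the same change as from compound 2 to compound 1, at a place described in the same words. Compound 4 is expected to show a step of about a 3.8-fold lower number from compound 3 to compound 4 (0.58 log units; beyond the scatter) because compound 3 stands at 2080 nM and because the earlier step made a 4.7-fold lower number from compound 2 to compound 1 (0.67 log units; beyond the scatter). Compound 4 is therefore estimated at 550 nM, between 200 nM and 1500 nM.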

Compound 4, concentration for 50% growth inhibition: 1690 nM
Estimate against measurement, compound 4: 3.1-fold (0.49 log units) below, and the stated range ends below it.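

On the core of compound 3, the same chloro group, placed on an aromatic carbon between two ring nitrogen atoms, gave a 1.2-fold lower number from compound 3 to compound 4 (0.09 log units; within the scatter) in this assay. Among the compounds shown here, the step seen on the first core therefore did not carry over at the same size to the second: the same change on two cores in this assay, a 4.7-fold lower number (0.67 log units; beyond the scatter) from compound 2 to compound 1 and a 1.2-fold lower number (0.09 log units; within the scatter) from compound 3 to compound 4, 3.8-fold (0.58 log units) apart, beyond the scatter of two such steps This shows that the size of this step can differ with the core, but it rests on only two pairs and does not show what sets the difference or how the change would behave on any further core.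

The compounds shown leave open whether an amine or a methoxy group on that same carbon would differ from the hydrogen of compound 3. They also leave open how either group would behave on the core of compound 2.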